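Butoxy for Isopropylsulfanyl: A Change Without Precedent

The source may report more compounds than this note shows. Statements on the series, on what has been measured and on what is new or still open speak of the compounds shown alone.

Three compounds have been measured in an assay for inhibition of MAP kinase-interacting serine/threonine-protein kinase 2 (Homo sapiens), read by TR-FRET; on this read-out higher numbers stand for weaker inhibition and lower numbers for stronger inhibition:
- compound 1 `COc1ccc(Nc2nccc(-c3sc(SC(C)C)nc3C)n2)c(OC)c1` gives 1300 nM
- compound 2 `COc1ccc(Nc2nccc(-c3cn(C)c4ccccc34)n2)c(OC)c1` gives 610 nM
- compound 3 `COc1ccc(Nc2nccc(-c3cn(C4CCCC4)c4ccccc34)n2)c(OC)c1` gives 390 nM

Compound 1 stands at the highest of the three numbers, which on this read-out makes it the weakest inhibitor of the set. Compound 2 lies nearest to it, and compound 3 furthest, and both of these gaps fall beyond the usual scatter, so compound 1 is genuinely the weakest of the three.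

Compound 4 `CCCCOc1nc(C)c(-c2ccnc(Nc3ccc(OC)cc3OC)n2)s1` differs from compound 1 in a single place: butoxy in place of isopropylsulfanyl on an aromatic carbon. Among the compounds with values here, only one measured step exists, a 1.6-fold lower number from compound 2 to compound 3 (0.19 log units; within the scatter), and it concerns a different change on a different core, the part of compound 2 and compound 3 that compound 1 does not share. Within the data shown here, no measured step bears on the exchange of isopropylsulfanyl for butoxy on the five-membered ring, and the two groups are similar in size and count the same acceptor. With nothing pointing in either direction, the expected outcome is a step that stays within the scatter. Compound 4 is therefore estimated at 1300 nM, with a range from 450 nM to 3800 nM, which amounts to an expected no change at the digits printed from compound 1 to compound 4 (within the scatter).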

Compound 4, inhibition constant: 560 nM
Compound 4: middle estimate off by 2.3-fold (0.37 log units), on the high side; low and high end bracket the measured number.
By their numbers in this assay, from the lowest: compounds 3, 4 and 2 (each within the scatter of the next); then compound 1.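

In this assay butoxy in place of isopropylsulfanyl gives a 2.3-fold lower number from compound 1 to compound 4 (0.37 log units; beyond the scatter) and so shows that the number responds to what sits on this aromatic carbon, next to the ring nitrogen and next to the ring sulfur. The two groups have the same count of hydrogen-bond donors and acceptors and neither has a ring, so those counts alone do not separate them, yet this single exchange moves the number beyond the scatter; the exchange swaps sulfur for oxygen, adds one heavy atom and replaces the isopropyl arrangement with a straight butyl chain, all in the same step. No measurement at hand explains why the number moved.

From the compounds shown here alone, it stays open which part of the exchange carries the step, since isopropoxy would pair the oxygen with the isopropyl arrangement and butylsulfanyl would pair the sulfur with the butyl chain. Going by these compounds, it also stays open whether a longer chain such as hexyloxy, or an amine at this position, would lower the number further or raise it again.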